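Allyl for ethyl on the triazole nitrogen of compound 3

A few compounds are considered here, and "the series" means these few. Any claim that something is new, unique, unknown or untested is made for them only; others in the source may bear on it.

Compound 1 `CCn1c(SCC(=O)Nc2ccc(/C(C)=N/O)cc2)nnc1-c1ccc(OC)c(OC)c1` gives 73% in a functional assay on the whole organism (strain albino) for inhibition, with Rattus norvegicus as the target, read by paw edema, with stated times of 30 min and 5 h, at a dose of 0.28 mmol/kg by the oral route; a higher number here means more inhibition at the dose given (going by the name of the read-out), a lower number less inhibition. Compound 2 `CCn1c(SCC(=O)Nc2ccc(C(C)=O)cc2)nnc1-c1ccc(OC)c(OC)c1` gives 66%, with a number 7 percentage points lower from compound 1 to compound 2 (within the scatter). Compound 3 `CCn1c(SCC(=O)Nc2ccc(C(C)=O)cc2)nnc1-c1cc(OC)c(OC)c(OC)c1` gives 64%, with a number 2 percentage points lower from compound 2 to compound 3 (within the scatter); the values of compound 3 and compound 1 also lie within the scatter of each other, so the three measured compounds are indistinguishable in this assay.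

Compound 4 `C=CCn1c(SCC(=O)Nc2ccc(C(C)=O)cc2)nnc1-c1cc(OC)c(OC)c(OC)c1` differs from compound 3 by vinyl in place of methyl on a saturated chain carbon bound to an aromatic nitrogen, or, read one bond further out, ethyl to allyl. Among the measured compounds shown here, no measured step touches the chain on the aromatic nitrogen: both earlier steps alter the aryl amide and the methoxy pattern, and both lie within the scatter. No step beyond the scatter is therefore expected, and a number 2 percentage points lower from compound 3 to compound 4 (within the scatter) is the estimated change. Compound 4 is expected to give 62%, with a range from 50% to 74%.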

Compound 4, a percentage reported as inhibition, in the whole organism at one dose (the size of the read-out at that dose, not a potency): 64%
Compound 4: the middle estimate sits 2 percentage points below what was measured, within the range that was stated.
By their numbers in this assay, from the lowest: compounds 3, 4, 2 and 1 (each within the scatter of the next).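

Ethyl to allyl, the first change read on the chain at the triazole nitrogen, shows no change at the digits printed from compound 3 to compound 4 (within the scatter) in this assay at this single oral dose. The chain on this aromatic nitrogen therefore accepts vinyl in place of methyl, with its added double bond, and the read-out stays within the scatter. Nothing available explains this result.

On these data alone, whether a longer chain such as butyl, or a chain ending in an amine or a carboxylic acid, would move the read-out beyond the scatter remains open. So does whether allyl gives the same reading with the dimethoxyphenyl and oxime groups of compound 1.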